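Methyl on the amide nitrogen: expected read-out for compound 3

The source may hold more compounds than are shown below. What is called first, only, known or untested is meant among the compounds shown, and "the series" means these compounds.

Compound 2 `CCNC(=O)[C@@H]1CN[C@H](C(=O)N2CCC[C@H]2C#N)C1` gives 60% in an assay on the whole organism (plasma, strain Sprague-Dawley) for inhibition of Dipeptidyl peptidase 4 (Rattus norvegicus), with a stated time of 6 h, at a dose of 1 mg/kg by the oral route; a lower number here means less inhibition, a higher number more inhibition at the dose given (going by the name of the read-out). Going by the values given here, this is the lowest of the two numbers in hand, yet its only neighbour, compound 1 `N#C[C@@H]1CCCN1C(=O)[C@@H]1C[C@H](C(=O)N2CCCCCCC2)CN1` with 63%, sits within the scatter. Among the compounds with values here, the one measured step, a number 3 percentage points lower from compound 1 to compound 2 (within the scatter), exchanged the group on the carbonyl carbon without a change beyond the scatter. Compound 3 `CCN(C)C(=O)[C@@H]1CN[C@H](C(=O)N2CCC[C@H]2C#N)C1` carries the change (methyl in place of hydrogen on an amide-type nitrogen). Within the data shown here, no measured step touches the amide nitrogen itself, so the data give no direction for this move. The step of a number 2 percentage points lower from compound 2 to compound 3 (within the scatter) is therefore expected to stay within the scatter. Compound 3 is estimated at 58%, with a range of 40% to 75%.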

Compound 3, a percentage reported as inhibition, in the whole organism at one dose (the size of the read-out at that dose, not a potency): 71%
The estimate for compound 3 lay 13 percentage points below the measured number, and the stated range covers the measured number.
By their numbers in this assay, from the lowest: compounds 2, 1 and 3 (each within the scatter of the next, the first and the last beyond it).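

In this assay, going by these compounds alone, the amide hydrogen is not neutral: methyl in its place gives a number 11 percentage points higher from compound 2 to compound 3 (beyond the scatter), the only step beyond the scatter. Against the eight-membered ring group on the carbonyl carbon, the ethyl(methyl)amino group gives a number 8 percentage points higher from compound 1 to compound 3 (within the scatter), so compound 1 and compound 3 remain unseparated. Nothing on hand explains the methyl step.

As far as these compounds go, whether the higher number of compound 3 holds with a second ethyl on this nitrogen, or with a pyrrolidine amide, stays open.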